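The source may report more compounds than this note shows. Statements on the series, on what has been measured and on what is new or still open speak of the compounds shown alone.

Compound 1 `Cc1ccncc1-c1cc(F)cc(-n2nnc(-c3ccccn3)n2)c1` and compound 2 `N#Cc1cccc(-n2nnc(-c3ncc[nH]3)n2)c1` have both been measured in an assay for binding affinity to metabotropic glutamate receptor 5 (Rattus norvegicus); on this read-out lower numbers stand for stronger inhibition and higher numbers for weaker inhibition. Compound 1 gives 1.8 nM in this assay, and compound 2 gives 34 nM. Of the two numbers, that of compound 2 is the higher one, and the gap to compound 1 is beyond the scatter, so compound 2 stands at the weaker end of what has been measured so far. Compound 3 `N#Cc1cccc(-n2nnc(-c3cc[nH]n3)n2)c1` has not yet been measured. It differs from compound 2 in one place: 1H-pyrazol-3-yl in place of 1H-imidazol-2-yl on an aromatic carbon. Both groups are five-membered aromatic rings with two nitrogen atoms, one hydrogen-bond donor and one hydrogen-bond acceptor, so the change is a rearrangement rather than an addition. Within the data shown here, no measured pair shows this kind of swap, so the expected step of a 1.2-fold higher number from compound 2 to compound 3 (0.07 log units; within the scatter) from compound 2 to compound 3 is modest and may not reach beyond the scatter. Compound 3 is therefore estimated at 40 nM, with a range from 10 nM to 160 nM.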

Compound 3, inhibition constant: > 2000 nM
Compound 3 ended at the assay's limit (the forecaster's own chance of this, stated with the estimate: 5%); middle value at least 50-fold (1.69 log units) away from the limit.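

Exchanging 1H-imidazol-2-yl for 1H-pyrazol-3-yl gives an at least 58-fold higher number from compound 2 to compound 3 (1.76 log units; beyond the scatter), although the two groups have the same heavy atoms and the same hydrogen-bond donor and acceptor counts. At this place on the five-membered aromatic ring with 4 nitrogen, the result therefore depends on how those atoms are joined, not only on which atoms are present or on those counts. The value of compound 3 in this assay is a limit of the assay and not a number, so the full size of the step stays unknown: the limit of > 2000 nM in this assay, at which 1 of the 3 values shown sits.

The two compounds cannot show which ring nitrogen or which hydrogen-bond donor accounts for the step, and compound 1 differs from both in more than one place. From the compounds shown here alone, it also remains open how a thiazol-2-yl or a 1-methylimidazol-2-yl group would behave at this place.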